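A few compounds are considered here, and "the series" means these few. Any claim that something is new, unique, unknown or untested is made for them only; others in the source may bear on it.

Compound 1 `CN(C)CCNc1n[n+]([O-])c2ccccc2[n+]1[O-]`: 50000000 nM. Compound 2 `CCCN(CCC)CCNc1n[n+]([O-])c2ccccc2[n+]1[O-]`: > 25000000 nM. Compound 3 `CCN(CC)CCNc1n[n+]([O-])c2ccc(Cl)cc2[n+]1[O-]`: 23000000 nM.

In a physicochemical assay for solubility, in the presence of a further agent that is not named here (on this read-out higher numbers stand for higher solubility and lower numbers for lower solubility), compound 1 gives 50000000 nM and compound 3 gives 23000000 nM, the lower of the two numbers, with compound 1 standing above it by a gap that is beyond the scatter. For compound 2 the reading of > 25000000 nM is a limit of the assay and not a number. Compound 4 `CCCN(CCC)CCNc1n[n+]([O-])c2ccc(Cl)cc2[n+]1[O-]` differs from compound 3 by dipropylamino in place of diethylamino on a saturated chain carbon, two bonds along the chain from a nitrogen on an aromatic ring. Among the compounds with values here, the one measured step of a related kind, a step that the limit leaves unreadable from compound 1 to compound 2, cannot be sized. That is because compound 2 sits at the limit of > 25000000 nM in this assay, at which 1 of the 3 values shown sits. No readable step therefore bears on the change, and the expected step of no change at the digits printed from compound 3 to compound 4 (within the scatter) is none beyond the scatter. Compound 4 is accordingly estimated at 23000000 nM, within 9000000 nM to 50000000 nM.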

Compound 4, solubility: 600000 nM
For compound 4 the middle estimate is 38-fold (1.58 log units) above the measured one; the measured number lies below the stated range.
By their numbers in this assay, from the lowest: compound 4; then compound 3; then compound 1.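

In this assay, within the data shown here, the change to dipropylamino on the saturated chain carbon now has a readable size, with a 38-fold lower number from compound 3 to compound 4 (1.58 log units; beyond the scatter) as a large step that no earlier pair could show. With dipropylamino held in place, chloro in place of hydrogen also reads as large, with an at least 41-fold lower number from compound 2 to compound 4 (1.61 log units; beyond the scatter) as its step. The reading for compound 2 in that step is a limit and not a number: the limit of > 25000000 nM in this assay, at which 1 of the 4 values shown sits.

As far as these compounds go, the step from compound 1 to compound 2 cannot be read, so whether the dipropylamino change has the same size without the chloro stays open. Also open, from the compounds shown here alone, is how a piperidine or morpholine in that place would read.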